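From methyl to methoxy on the aromatic ring

The compounds below may be only part of what the source reports. "The series", "measured", "known", "first", "only" and "open" are said of these compounds alone.

Measured in a functional assay on HeLa cells (Homo sapiens) for antiproliferative activity, read by MTT assay, with a stated time of 72 h; a higher number here means a weaker inhibitor, a lower number a stronger inhibitor:
Compound 1 `CC(=O)NNC(=O)c1csc2ncc(-c3ccc(C)cc3)n12`: 74200 nM
Compound 2 `CCC(=O)NNC(=O)c1csc2ncc(-c3ccc(C)cc3)n12`: 13000 nM

Compound 1 has the higher number of the two, which makes it the weaker inhibitor in this assay. The next compound, compound 3 `COc1ccc(-c2cnc3scc(C(=O)NNC(C)=O)n23)cc1`, keeps the core of compound 1 and changes one group: methoxy in place of methyl on an aromatic carbon, para to a large group (methoxy in place of methyl on an aromatic carbon). For the measured compounds named here, the only measured step, a 5.7-fold lower number from compound 1 to compound 2 (0.76 log units; beyond the scatter), is modest and concerns a saturated chain carbon, not this aromatic carbon, so it offers no direct guide. Going by the values given here, with no measured step at this place, no change beyond the scatter is expected in this assay, in either direction, although a modest shift remains possible. The estimated change is a 1.2-fold lower number from compound 1 to compound 3 (0.09 log units; within the scatter). For compound 3 the expected value is 60000 nM, with an estimated range of 20000 nM to 180000 nM.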

Compound 3, half-maximal inhibitory concentration: 17900 nM
The estimate for compound 3 lay 3.4-fold (0.53 log units) above the measured number; measured number below the stated range.
By their numbers in this assay, from the lowest: compounds 2 and 3 (each within the scatter of the next); then compound 1.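

In this assay, this aromatic carbon, para to a large group, responds to the swap of methyl for methoxy, with a 4.1-fold lower number from compound 1 to compound 3 (0.62 log units; beyond the scatter). The earlier step, a 5.7-fold lower number from compound 1 to compound 2 (0.76 log units; beyond the scatter), lies at a saturated chain carbon, so two separate places on compound 1 have now each shown a modest change beyond the scatter. Nothing available explains how methoxy produces this change.

The compounds shown leave open whether an amine or a chlorine at this aromatic carbon would shift the number further. They also leave open whether methoxy and the longer chain of compound 2, brought together in one molecule, would lower it more than either change alone.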